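The source may report more compounds than this note shows. Statements on the series, on what has been measured and on what is new or still open speak of the compounds shown alone.

Measured in a functional assay on CCRF-CEM cells (Homo sapiens) for antiproliferative activity, read by MTT assay, with a stated time of 24 h, tested at 100 uM; on this read-out higher numbers stand for a weaker effect at the one concentration tested and lower numbers for a stronger effect:
- compound 1 `OC(CCn1nc2c(Br)c(Br)c(Br)c(Br)c2n1)c1ccc(Br)cc1`: 0%
- compound 2 `C[C@@H](O)CCn1nc2c(Br)c(Br)c(Br)c(Br)c2n1`: 36%
- compound 3 `OC(CCn1nc2c(Br)c(Br)c(Br)c(Br)c2n1)c1cccc(Cl)c1`: 0%

Compound 3 stands level with compound 1 at the digits printed, and the two together sit at the lowest of the three numbers in this assay; compound 2, with a methyl on the carbon bound to oxygen in place of an aryl, gives a number higher by a margin that is beyond the scatter. Within the data shown here, the one step measured within this set is no change at the digits printed from compound 1 to compound 3 (within the scatter), so exchanging 4-bromophenyl for 3-chlorophenyl on the saturated chain carbon bound to an oxygen left the read-out where it was.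

Compound 4 `OC(CCn1nc2c(Br)c(Br)c(Br)c(Br)c2n1)c1ccc(Cl)cc1` is not yet measured. It differs from compound 3 as follows: 4-chlorophenyl in place of 3-chlorophenyl on a saturated chain carbon bound to an oxygen on a saturated carbon and a saturated chain carbon. Among the measured compounds shown here, the only step that bears on this is the one from compound 1 to compound 3, where a change of halogen and position on the same aryl produced no change within the scatter. Compound 1 already carries a 4-halophenyl at this carbon and gives the same low number as compound 3. On that basis no step beyond the scatter is expected for this assay, and the estimated step of a number 3 percentage points higher from compound 3 to compound 4 (within the scatter) is expected to be close to nil.

Compound 4 is therefore estimated at 3%, within a range from 0% to 15%.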

Compound 4, a percentage reported as activity, at one concentration (the size of the read-out at that concentration, not a potency): 0%
Compound 4: the middle estimate sits 3 percentage points above what was measured; low and high end bracket the measured number.
By their numbers in this assay, from the lowest: compounds 1, 3 and 4 (each within the scatter of the next); then compound 2.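

In this assay, moving the chlorine on the aryl group gives no change at the digits printed from compound 3 to compound 4 (within the scatter), so 4-chlorophenyl in place of 3-chlorophenyl tests the position of the halogen alone, which the earlier step had changed together with the halogen itself. Chloro in place of bromo on an aromatic carbon gives no change at the digits printed from compound 1 to compound 4 (within the scatter), which now tests the identity of the halogen alone at that same ring position, so neither single change moves the read-out at the digits printed. No measurement on hand offers an explanation for this lack of response.

As far as these compounds go, compound 1, compound 3 and compound 4 share one number at a single concentration, the lowest in the set, so any difference among them that would appear only at lower concentrations remains open. Also open, from the compounds shown here alone, is how the read-out would respond at the same saturated chain carbon to a phenyl with no halogen, a 4-methoxyphenyl or a pyridyl ring, or to an amine or a carboxylic acid on the aryl group.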